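This account rests on a few compounds, and the source may have more. Where it says the series, first, only, none or still open, it means among the compounds named here.

Working notes on the series. Compound 1 `CN(C)CCn1cnnc1-c1cc(Oc2ccc(NC(=O)N/N=C/c3ccc(F)cc3F)cc2F)ccn1` carries a 2,4-difluorophenyl on the carbon with a double bond to nitrogen; in a functional assay on A549 cells (Homo sapiens) for cytotoxicity, read by MTT assay, with a stated time of 72 h (a higher number here means a weaker inhibitor, a lower number a stronger inhibitor), compound 1 gives 1870 nM, the lowest of the two numbers shown, with compound 3 the nearest. Compound 3 `CN(C)CCn1cnnc1-c1cc(Oc2ccc(NC(=O)N/N=C/c3ccc(O)cc3O)cc2F)ccn1` gives 12700 nM, a step of a 6.8-fold higher number from compound 1 to compound 3 (0.83 log units; beyond the scatter). Compound 2 `COc1cc(/C=N/NC(=O)Nc2ccc(Oc3ccnc(-c4nncn4CCN(C)C)c3)c(F)c2)ccc1O` stops at > 100000 nM, which is a limit of the assay and not a number. That value sits at the limit of > 100000 nM in this assay, at which 1 of the 3 values shown sits. The step of an at least 53-fold higher number from compound 1 to compound 2 (1.72 log units; beyond the scatter) is therefore a bound rather than a measured gap, and an at least 7.8-fold lower number from compound 2 to compound 3 (0.89 log units; beyond the scatter) is likewise a bound.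

Compound 4 `Cc1cc(/C=N/NC(=O)Nc2ccc(Oc3ccnc(-c4nncn4CCN(C)C)c3)c(F)c2)cc(C)c1O` differs from compound 1 by 4-hydroxy-3,5-dimethylphenyl in place of 2,4-difluorophenyl on a carbon with a double bond to nitrogen. Both measured steps from compound 1 swap the 2,4-difluorophenyl for a phenyl bearing a hydroxy group and both raise the number: a 6.8-fold higher number from compound 1 to compound 3 (0.83 log units; beyond the scatter) and an at least 53-fold higher number from compound 1 to compound 2 (1.72 log units; beyond the scatter). A rise beyond the scatter is therefore expected for compound 4 as well, of a size lying between those two steps, with the direction toward weaker inhibition. Compound 4 is estimated at 15000 nM, in the range 4000 nM to 60000 nM. That estimate is expected to correspond to a step of an 8.0-fold higher number from compound 1 to compound 4 (0.90 log units; beyond the scatter).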

Compound 4, half-maximal inhibitory concentration: 1640 nM
For compound 4 the middle estimate is 9.1-fold (0.96 log units) above the measured one; measured number below the stated range.
By their numbers in this assay, from the lowest: compounds 4 and 1 (each within the scatter of the next); then compound 3. At a limit, above all of these: compound 2.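

A hydroxy group on the phenyl does not by itself go with a higher number in this assay: compound 4 goes against the trend set by compounds 2 and 3. The step here is a 1.1-fold lower number from compound 1 to compound 4 (0.06 log units; within the scatter), so 4-hydroxy-3,5-dimethylphenyl and 2,4-difluorophenyl cannot be told apart at this position. Among the phenyls bearing hydroxy groups, the rest of the substitution pattern now matters, as shown by a 7.7-fold lower number from compound 3 to compound 4 (0.89 log units; beyond the scatter). The step of an at least 60-fold lower number from compound 2 to compound 4 (1.78 log units; beyond the scatter) points the same way but is only a bound, compound 2 being at a limit of the assay: the limit of > 100000 nM in this assay, at which 1 of the 4 values shown sits.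

Whether the two methyl groups account for the gap between compound 4 and compounds 2 and 3 remains open, and a plain 4-hydroxyphenyl or a 3,5-dimethylphenyl on this carbon would separate the contribution of the methyl groups from that of the hydroxy group. Going by these compounds, how far this position tolerates other groups is also open, for instance an amine, a carboxylic acid or a longer alkoxy chain on the phenyl in place of the hydroxy group.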